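Ethoxy to propoxy on two cores: stability notes

The compounds below may be only part of what the source reports. "The series", "measured", "known", "first", "only" and "open" are said of these compounds alone.

Measured so far:
compound 1, `CCO[C@@H]1O[C@H](CNC(=O)c2ccc(S(N)(=O)=O)cc2)[C@@H](O)[C@H](O)[C@H]1N`: 58.6 h
compound 2, `CCCO[C@@H]1O[C@H](CNC(=O)c2ccc(S(N)(=O)=O)cc2)[C@@H](O)[C@H](O)[C@H]1N`: 64.4 h
compound 3, `CCO[C@@H]1O[C@H](CNC(=O)c2ccc(S(N)(=O)=O)cc2)[C@@H](O)[C@H](O)[C@@H]1O`: 61.6 h

The series has one change made on two cores. In an ADME assay on microsomes from liver (Mus musculus) for metabolic stability (on this read-out lower numbers stand for a shorter-lived compound and higher numbers for a longer-lived compound), compound 1 gives 58.6 h and compound 2 gives 64.4 h. The pair differs by methyl in place of hydrogen on a saturated chain carbon, two bonds along the chain from an oxygen on a saturated carbon, and the step is a 1.1-fold higher number from compound 1 to compound 2 (0.04 log units; within the scatter). Compound 3 has a different core; in this assay compound 3 gives 61.6 h. The difference between the core of compound 1 and the core of compound 3 is not broken down here, and the numbers of compound 1, compound 2 and compound 3 all lie within the scatter of one another, so no order among them can be read.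

Compound 4, `CCCO[C@@H]1O[C@H](CNC(=O)c2ccc(S(N)(=O)=O)cc2)[C@@H](O)[C@H](O)[C@@H]1O`, has not been measured in this assay. It differs from compound 3 by methyl in place of hydrogen on a saturated chain carbon, two bonds along the chain from an oxygen on a saturated carbon, and since the place is the same in both pairs this is the same change as that from compound 1 to compound 2. Going by the values given here, the only guide to its size is the one measured instance: because a 1.1-fold higher number from compound 1 to compound 2 (0.04 log units; within the scatter) was within the scatter, the step of a 1.1-fold higher number from compound 3 to compound 4 (0.03 log units; within the scatter) is expected to be of the same small size. On that basis compound 4 is expected to give about 66 h in this assay, with the range 38 h to 115 h covering the usual spread of repeated measurements.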

Compound 4, half-life: 64.5 h
Beside the measured number, compound 4's estimate is 1.0-fold (0.01 log units) above it; measured number inside the range.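

Working notes on the transfer: in this assay, methyl in place of hydrogen on a saturated chain carbon, two bonds along the chain from an oxygen on a saturated carbon, gives a 1.0-fold higher number from compound 3 to compound 4 (0.02 log units; within the scatter) on the core of compound 3. Set beside the earlier step, the ethoxy to propoxy change reads alike on both cores, with no measurable difference between the two steps: the same change on two cores in this assay, a 1.1-fold higher number (0.04 log units; within the scatter) from compound 1 to compound 2 and a 1.0-fold higher number (0.02 log units; within the scatter) from compound 3 to compound 4, 1.0-fold (0.02 log units) apart, within the scatter of two such steps. Going by these compounds alone, this shows only that the change leaves the half-life within the scatter on both cores; it does not show a real gain from the longer chain, and two pairs with small steps cannot establish a rule for the series or predict the change on any further core.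

Still open, from the compounds shown here alone, is whether a longer chain than propoxy, such as butoxy or a branched chain, or a carboxylic acid on that chain, would move the half-life beyond the scatter on either core. The compounds shown also leave open whether the two cores would part once a change of larger size is made, and whether the match between the steps holds on any other read-out.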